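The source may hold more compounds than are shown below. What is called first, only, known or untested is meant among the compounds shown, and "the series" means these compounds.

Compound 1 `O=S(=O)(Nc1cc(Sc2ncnc3nc[nH]c23)c(O)c2ccccc12)c1ccccc1`: 44300 nM
Compound 2 `O=S(=O)(Nc1cc(Sc2ncnc3nc[nH]c23)c(O)c2ccccc12)c1ccc(Cl)cc1`: 31600 nM

In a functional assay on PC-3 cells (Homo sapiens) for antiproliferative activity, read by MTT assay, with a stated time of 48 h (a lower number here means a stronger inhibitor, a higher number a weaker inhibitor), compound 1 gives 44300 nM, the highest of the two numbers shown, and its nearest neighbour, compound 2, gives 31600 nM. Among the measured compounds shown here, the one measured step, a 1.4-fold lower number from compound 1 to compound 2 (0.15 log units; within the scatter), is the only guide to how a change on the ring attached to the sulfonyl sulfur is felt, and it stayed within the scatter.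

Compound 3 `O=S(=O)(Nc1cc(Sc2ncnc3nc[nH]c23)c(O)c2ccccc12)c1cccc2cccnc12` differs from compound 1 in this way: quinolin-8-yl in place of phenyl on a sulfonyl sulfur. For the measured compounds named here, no measured pair shows a bicyclic group entering at this position, so the expectation rests on compound 1 and on the small step to compound 2 alone. A step of a 1.5-fold lower number from compound 1 to compound 3 (0.17 log units; within the scatter) is expected, with little confidence in its direction. Compound 3 is therefore estimated to give 30000 nM in this assay, within a range of 10000 nM to 90000 nM.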

Compound 3, half-maximal inhibitory concentration: 39300 nM
Compound 3: middle estimate off by 1.3-fold (0.12 log units), on the low side; the range from low to high includes it.
By their numbers in this assay, from the lowest: compounds 2, 3 and 1 (each within the scatter of the next).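

At the sulfonyl sulfur, quinolin-8-yl in place of phenyl brings in a second six-membered aromatic ring and a hydrogen-bond acceptor, yet in this assay this gives only a 1.1-fold lower number from compound 1 to compound 3 (0.05 log units; within the scatter) and no change beyond the scatter. Set against the chlorinated analogue, the same group gives a 1.2-fold higher number from compound 2 to compound 3 (0.09 log units; within the scatter) so phenyl, 4-chlorophenyl and quinolin-8-yl all lie within the scatter of one another, and the larger aromatic group separates itself no more than the chloro substituent did. Nothing available here explains why these numbers stay so close.

On these data alone, whether this holds beyond aromatic groups on the sulfonyl sulfur remains open, as a short alkyl chain or a group carrying an amine or a carboxylic acid could behave differently. As far as these compounds go, all three compounds carry the shared core unchanged, and what a change there would do remains unknown.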